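The source may report more compounds than this note shows. Statements on the series, on what has been measured and on what is new or still open speak of the compounds shown alone.

Measured so far:
compound 1, `O=C(NCc1ccc(S(=O)(=O)c2ccc(F)c(F)c2)cc1)c1cc2cnccc2[nH]1` — 58%
compound 2, `O=C(NCc1ccc(S(=O)(=O)N2CCCCC2)cc1)c1cc2ccncc2[nH]1` — "below limit of detection" (no number reported)

In an ADME assay on microsomes from liver (Mus musculus) for metabolic stability, read by LC-MS, with a stated time of 30 min, tested at 1 uM (on this read-out lower numbers stand for a less stable compound and higher numbers for a more stable compound), compound 1 gives 58%. For compound 2 the result in this assay is "below limit of detection" (no number reported), and no number stands behind it. Compound 1 therefore holds the only number shown in this assay, and the one further entry, compound 2, offers no single value to set beside it. The untested compound 3, `O=C(NCc1ccc(S(=O)(=O)c2ccccc2)cc1)c1cc2cnccc2[nH]1`, differs from compound 1 at one place: phenyl in place of 3,4-difluorophenyl on a sulfonyl sulfur. Among the measured compounds shown here, no step between two measured compounds is available, so the size of this change in this assay cannot be read off another pair and can only be expected. The expected step is a number 13 percentage points lower from compound 1 to compound 3 (beyond the scatter), a modest move downward that may reach the edge of the scatter but is not expected to go far past it. Compound 3 is accordingly estimated at 45%, with a range from 25% to 65%.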

Compound 3, percent of the compound remaining: 54%
For compound 3 the middle estimate is 9 percentage points below the measured one, and the stated range covers the measured number.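

In this assay, among the compounds shown here, phenyl in place of 3,4-difluorophenyl on a sulfonyl sulfur gives a number 4 percentage points lower from compound 1 to compound 3 (within the scatter), the first step in this set that can be read between two measured compounds. This read-out therefore does not tell the two groups apart, and for this pair the two fluorine atoms of compound 1 make no difference that can be separated from ordinary repeat variation. Nothing measured alongside this result offers an explanation for it.

The compounds shown leave open whether a group of another kind on the sulfonyl sulfur, such as a pyridine ring, a methoxyphenyl group or a short alkyl chain, would also leave this assay where compound 1 and compound 3 stand, or would move it beyond the usual scatter. They also leave open how a single fluorine on the phenyl would read, and whether changes elsewhere on the shared core, for example a methyl group on the amide nitrogen, would matter more than this one.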